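Replacing an Aryl Urea Terminus with a Hydrophilic Chain

The compounds below may be only part of what the source reports. "The series", "measured", "known", "first", "only" and "open" are said of these compounds alone.

The series was tested in a functional assay on HeLa cells (Homo sapiens) for inhibition, read by MTT assay, with a stated time of 4 days; a higher number here means a weaker inhibitor, a lower number a stronger inhibitor. Compound 1 `CCOC(=O)NC(c1ccccc1)c1ccc(Cl)cc1` reached only the limit of this assay, > 250000 nM, and gave no number (the limit of > 250000 nM in this assay, at which 1 of the 3 values shown sits). Compound 2 `COc1cc(NC(C)CCCNC(=O)NCCNC(c2ccccc2)(c2ccccc2)c2ccccc2)c2ncccc2c1` gave 38000 nM in this assay. Compound 3 `COc1cc(NC(C)CCCNC(=O)Nc2ccc(Cl)c(C(F)(F)F)c2)c2ncccc2c1` gave 3900 nM, the lowest of the two numbers recorded, standing well apart from compound 2, whose value is beyond the usual scatter of this assay.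

Compound 4 `COc1cc(NC(C)CCCNC(=O)NNC(=O)NCCO)c2ncccc2c1` has not yet been measured. It differs from compound 3 in one place: ((2-hydroxyethyl)carbamoyl)amino in place of 4-chloro-3-(trifluoromethyl)phenyl on an amide-type nitrogen. Among the measured compounds shown here, no pair of measured compounds shows the effect of such an exchange, so the expectation rests on the two numbers alone and on the size of the change.

The step from compound 3 to compound 4 is expected to be a 7.7-fold higher number from compound 3 to compound 4 (0.89 log units; beyond the scatter) in this assay, a loss of potency beyond the scatter. Compound 4 is estimated to give 30000 nM in this assay, with a likely range from 8000 nM to 150000 nM.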

Compound 4, half-maximal inhibitory concentration: 196000 nM
The estimate for compound 4 lay 6.5-fold (0.82 log units) below the measured number; the measured number lies above the stated range.
By their numbers in this assay, from the lowest: compound 3; then compound 2; then compound 4. At a limit, above all of these: compound 1.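

In this assay, among the compounds shown here, putting ((2-hydroxyethyl)carbamoyl)amino in place of 4-chloro-3-(trifluoromethyl)phenyl on the amide-type nitrogen gives a 50-fold higher number from compound 3 to compound 4 (1.70 log units; beyond the scatter) in the first measured step at this position. This shows that the position does not accept every terminus, and that this ring-free chain, with its added hydrogen-bond donors and acceptors, is a poor replacement for the halogenated aryl group in this series. Nothing measured among these compounds accounts for the size of the step.

For the compounds shown here, the single step cannot separate the loss of the aryl ring from the entry of this particular chain. On these data alone, whether an unsubstituted phenyl ring, a terminal amine, a carboxylic acid or a longer chain on the same nitrogen would keep the potency of compound 3 remains open.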